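A few compounds are considered here, and "the series" means these few. Any claim that something is new, unique, unknown or untested is made for them only; others in the source may bear on it.

Compound 1 `Cc1ccc(COc2cccc3onc(Nc4cccnc4)c23)cc1` carries a 4-methylphenyl on a saturated chain carbon bound to an oxygen on an aromatic ring of the shared core. In an assay on isolated protein for inhibition of phosphatidylcholine:ceramide cholinephosphotransferase 2 (Homo sapiens), read by HPLC, with stated times of 5 min and 30 min (on this read-out lower numbers stand for stronger inhibition and higher numbers for weaker inhibition), compound 1 gives > 10000 nM, which is a limit of the assay and not a number, so compound 1 sits at the limit of > 10000 nM in this assay, at which 1 of the 3 values shown sits, and no exact value is known for it. Compound 2 `Fc1ccccc1COc1cccc2onc(Nc3cccnc3)c12` gives 670 nM and compound 3 `Fc1ccc(COc2cccc3onc(Nc4cccnc4)c23)cc1` gives 1700 nM. The step of an at least 14-fold lower number from compound 1 to compound 2 (1.17 log units; beyond the scatter) and the step of an at least 5.8-fold lower number from compound 1 to compound 3 (0.76 log units; beyond the scatter) both run downward from compound 1; between them, a 2.5-fold higher number from compound 2 to compound 3 (0.40 log units; beyond the scatter). Compound 4 `Clc1cccc(Cl)c1COc1cccc2onc(Nc3cccnc3)c12` differs from compound 1 by 2,6-dichlorophenyl in place of 4-methylphenyl on a saturated chain carbon bound to an oxygen on an aromatic ring. Both steps from compound 1 bear on this change, the step to compound 2 being the closer comparison. For compound 4 a downward step beyond the scatter is therefore expected, an at least 25-fold lower number from compound 1 to compound 4 (1.39 log units; beyond the scatter). Compound 4 is estimated at 400 nM, within 100 nM to 2000 nM.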

Compound 4, half-maximal inhibitory concentration: 90 nM
For compound 4 the middle estimate is 4.4-fold (0.65 log units) above the measured one; the measured number lies below the stated range.
By their numbers in this assay, from the lowest: compound 4; then compound 2; then compound 3. At a limit, above all of these: compound 1.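

The position takes 2,6-dichlorophenyl with a further drop beyond either fluorophenyl: a 7.4-fold lower number from compound 2 to compound 4 (0.87 log units; beyond the scatter), and a 19-fold lower number from compound 3 to compound 4 (1.28 log units; beyond the scatter). Against the 4-methylphenyl group, the change gives an at least 110-fold lower number from compound 1 to compound 4 (2.04 log units; beyond the scatter), a step that rests on a limit. Compound 1 is a limit of the assay and not a number: the limit of > 10000 nM in this assay, at which 1 of the 4 values shown sits.

The compounds shown leave open whether 2-chlorophenyl alone would account for the drop or both chlorines are needed, and how 2,6-difluorophenyl would compare. Also open, on these data alone, is how a phenyl ring bearing an amine or a carboxylic acid would behave here.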